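The source may hold more compounds than are shown below. What is called first, only, known or untested is meant among the compounds shown, and "the series" means these compounds.

In a functional assay on PC-3 cells (Homo sapiens) for inhibition, read by sulforhodamine B assay, with a stated time of 48 h (on this read-out lower numbers stand for stronger inhibition of growth and higher numbers for weaker inhibition of growth), compound 1 `CC1(/C=C/c2ccc(C(F)(F)F)cc2)C=CC(=O)O1` gives 13100 nM. This is the lower of the two numbers available, and it lies beyond the scatter from compound 2 `CC1(/C=C/c2cccc(O)c2)C=CC(=O)O1`, which gives 98800 nM. The next analogue is compound 3 `CC1(/C=C/c2ccc(O)cc2)C=CC(=O)O1`, which has hydroxy in place of trifluoromethyl on an aromatic carbon, para to a group of 9 heavy atoms (hydroxy in place of trifluoromethyl on an aromatic carbon). Within the data shown here, no matched step between measured compounds is available in this assay, so any expectation for this change rests on thin evidence. Compound 2 also carries hydroxy and stands at 98800 nM, which suggests weaker growth inhibition for compound 3 than for compound 1. The expected step, a 5.0-fold higher number from compound 1 to compound 3 (0.70 log units; beyond the scatter), is upward and beyond the scatter. The estimated value for compound 3 is 65000 nM, with an expected range of 25000 nM to 170000 nM.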

Compound 3, concentration for total growth inhibition: 138000 nM
Compound 3: middle estimate off by 2.1-fold (0.33 log units), on the low side, and the stated range covers the measured number.
By their numbers in this assay, from the lowest: compound 1; then compounds 2 and 3 (each within the scatter of the next).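

In this assay, among these compounds, the first matched step at this position, on an aromatic carbon para to a group of 9 heavy atoms, is large: hydroxy in place of trifluoromethyl gives an 11-fold higher number from compound 1 to compound 3 (1.02 log units; beyond the scatter) and so weaker growth inhibition. The advantage of compound 1 therefore now rests on a change in one place, and not only on its gap to compound 2, which also carries hydroxy but differs from compound 1 in more than one place. No measurement on hand accounts for the size of this step.

Among the compounds shown here, with only two groups compared at this position, it remains open whether the number tracks the loss of trifluoromethyl or the arrival of hydroxy. Methoxy, chlorine or an amine at the same carbon could help separate these two readings, and whether any group gives a lower number than compound 1 is also unresolved.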